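The source may hold more compounds than are shown below. What is called first, only, known or untested is meant among the compounds shown, and "the series" means these compounds.

Compound 3 `CCCCCCCC/C=C\CCCCCCCCNC(=O)Nc1ccc(OC)cc1OC` gives 5400 nM in an assay on microsomes from intestinal mucosa for inhibition of acyl-CoA:cholesterol acyltransferase (Oryctolagus cuniculus) (a lower number here means a stronger inhibitor, a higher number a weaker inhibitor), the highest of the two numbers shown. Its nearest neighbour, compound 1 `CCCCCCCC/C=C\CCCCCCCCNC(=O)Nc1c(OC)cc(OC)cc1OC`, gives 320 nM, and the gap, a 17-fold higher number from compound 1 to compound 3 (1.23 log units; beyond the scatter), arises from hydrogen in place of methoxy on an aromatic carbon. Compound 2 `CCCCCCCC/C=C\CCCCCCCC(=O)Oc1c(C)cccc1C`, an ester rather than a urea, reaches only a limit and not a number, > 10000 nM, which is the limit of > 10000 nM in this assay, at which 1 of the 3 values shown sits. Compound 4 `CCCCCCCC/C=C\CCCCCCCCNC(=O)Nc1c(C)cccc1Cl` carries 2-chloro-6-methylphenyl in place of 2,4-dimethoxyphenyl on an amide-type nitrogen. Within the data shown here, the only measured step bearing on this, a 17-fold higher number from compound 1 to compound 3 (1.23 log units; beyond the scatter), shows that losing one methoxy sharply raised the number; compound 4 loses both methoxy groups and gains chlorine and methyl, for which no measured step exists. A rise beyond the scatter, a 1.3-fold higher number from compound 3 to compound 4 (0.11 log units; within the scatter), is expected, with a real chance of a limit. Compound 4 is estimated at 7000 nM, between 1500 nM and 30000 nM.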

Compound 4, half-maximal inhibitory concentration: 180 nM
For compound 4 the middle estimate is 39-fold (1.59 log units) above the measured one; the whole stated range lies above it.
By their numbers in this assay, from the lowest: compounds 4 and 1 (each within the scatter of the next); then compound 3. At a limit, above all of these: compound 2.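

In this assay, among these compounds, 2-chloro-6-methylphenyl in place of 2,4-dimethoxyphenyl on an amide-type nitrogen gives a 30-fold lower number from compound 3 to compound 4 (1.48 log units; beyond the scatter) and so reverses the picture from the earlier compounds. Compound 1 and compound 3 alone suggested that this ring needed its methoxy groups for a low number, yet compound 4 reaches a low number with none. Nothing measured here explains this change.
Whether the chlorine or the methyl accounts for the drop stays open, since both enter together. How an amine or a carboxylic acid on this ring would fare is also unknown.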